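This account rests on a few compounds, and the source may have more. Where it says the series, first, only, none or still open, it means among the compounds named here.

Measured so far:
- compound 1 `CC1(C)C=C(n2ccccc2=O)c2cc(C(=O)c3cccs3)ccc2O1`: 6.4
- compound 2 `CC1(C)C=C(n2ccccc2=O)c2cc(OC(=O)Nc3ccccc3F)ccc2O1`: 5.38
- compound 3 `CC1(C)C=C(n2ccccc2=O)c2cc(OC(=O)Nc3ccccc3C(F)(F)F)ccc2O1`: 5.58

In a functional assay (aorta) with Rattus norvegicus as the target (a higher number here means a more potent compound, by a factor of ten per unit of this negative logarithm, a lower number a less potent compound), compound 1 stands highest of the three numbers; its lead over compound 3 and over compound 2 lies beyond the scatter in both cases, so compound 1 is the most potent compound of the set. Within the two carbamates the only one-place step, a number 0.20 log units higher from compound 2 to compound 3 (within the scatter), is within the scatter.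

Compound 4 `CC1(C)C=C(n2ccccc2=O)c2cc(C(F)(F)F)ccc2O1` has not yet been measured in this assay. Compared with compound 1 the change is trifluoromethyl in place of (thiophen-2-yl)carbonyl on an aromatic carbon. Within the data shown here, no measured step touches this change: the carbamates of compound 2 and compound 3 carry a different linkage at the same position, and the one step between them exchanges only a fluoro for a trifluoromethyl on the attached ring. Among the measured compounds shown here, the values of compound 2 and compound 3 show only that a different group at this position leaves the number well under that of compound 1. With nothing closer to go on, a modest drop from compound 1 is expected, a number 0.40 log units lower from compound 1 to compound 4 (beyond the scatter), with a wide range. Compound 4 is therefore estimated at 6, between 5.2 and 6.8.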

Compound 4, logarithm of the reciprocal of the active concentration, log(1/C): 7.61
For compound 4 the middle estimate is 1.61 log units below the measured one; the whole stated range lies below it.
By their numbers in this assay, from the lowest: compounds 2 and 3 (each within the scatter of the next); then compound 1; then compound 4.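

In this assay, the step of a number 1.21 log units higher from compound 1 to compound 4 (beyond the scatter) shows that the number at this aromatic carbon can rise well past the level set by compound 1. Neither the thiophene ring nor the carbonyl of the (thiophen-2-yl)carbonyl group is therefore needed for a high number on the shared core: trifluoromethyl, with no ring and no hydrogen-bond acceptors, gives the highest number among the compounds shown. No available measurement accounts for the size of this step.

Among these compounds, the single exchange cannot separate the contribution of the entering trifluoromethyl from that of the leaving (thiophen-2-yl)carbonyl. Going by these compounds, what a nitrile, an amine or a carboxylic acid on this aromatic carbon would give remains open, as does whether trifluoromethyl holds its advantage with another group in place of the ring bearing the carbonyl on the shared core.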